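Sulfoxide to Sulfone on a Triazole Core in Mice

The source may report more compounds than this note shows. Statements on the series, on what has been measured and on what is new or still open speak of the compounds shown alone.

Compound 1 `Cn1c(-c2cccc3ccccc23)nnc1[S+](C)[O-]` and compound 2 `Cn1c(-c2cccc3ccccc23)nnc1S(C)(=O)=O` share a core; how it differs from the core of compound 3 `Cn1c(-c2ccccc2F)nnc1[S+](C)[O-]` is not broken down here. In a functional assay on the whole organism for antagonist activity, with Mus musculus as the target (a lower number here means that less compound is needed, a higher number that more compound is needed for the effect), compound 1 gives only a limit, > 200 mg/kg. Compound 2 likewise gives only a limit in this assay, > 200 mg/kg. The change between them, (a group of 4 heavy atoms (1 carbon, 2 oxygen, 1 sulfur; no ring) in place of a group of 3 heavy atoms (1 carbon, 1 oxygen, 1 sulfur; no ring), on an aromatic carbon), yields a step that the two limits leave unreadable from compound 1 to compound 2, and the limit of > 200 mg/kg in this assay, at which 2 of the 3 values shown sit, shows why no size can be read. Among the compounds with values here, compound 3 gives 20 mg/kg in this assay, the only number among the three. Compound 4 `Cn1c(-c2ccccc2F)nnc1S(C)(=O)=O` carries the same kind of change, (a group of 4 heavy atoms (1 carbon, 2 oxygen, 1 sulfur; no ring) in place of a group of 3 heavy atoms (1 carbon, 1 oxygen, 1 sulfur; no ring), on an aromatic carbon). Within the data shown here, no measured step gives a size for this change. Compound 4 is expected at 30 mg/kg, between 10 mg/kg and 120 mg/kg, an estimated step of a 1.5-fold higher number from compound 3 to compound 4 (0.18 log units; within the scatter).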

Compound 4, dose for half-maximal effect: 17.6 mg/kg
Compound 4: the middle estimate sits 1.7-fold (0.23 log units) above what was measured; the measured number falls inside the stated range.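

With methylsulfonyl in place of the earlier group on the core of compound 3, this assay shows a 1.1-fold lower number from compound 3 to compound 4 (0.06 log units; within the scatter), so on this core the two compounds cannot be told apart. On the core of compound 1 the same change has no readable size, because compound 1 and compound 2 both give only a limit: the limit of > 200 mg/kg in this assay, at which 2 of the 4 values shown sit. The change can therefore be read on one core only, and the data do not show whether its result carries over from one core to the other.

Still open, as far as these compounds go, is how an amine or a carboxylic acid would behave on this same aromatic carbon. From the compounds shown here alone, a longer chain on the sulfur, in place of the single carbon, also remains open.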